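Compound 4 and the loss of the ureido group

A few compounds are considered here, and "the series" means these few. Any claim that something is new, unique, unknown or untested is made for them only; others in the source may bear on it.

Measured so far in an ADME assay for permeability, using PAMPA, with a stated time of 4 h, at pH 5.5 (a lower number here means that the compound crosses the layer more slowly, a higher number that the compound crosses the layer faster), are three compounds.

Compound 1 `NCCCCN(C[C@H]1Cc2cccnc2CN1)[C@H]1CCCc2cccnc21` gives 2 nm/s
Compound 2 `NCCCCN(C[C@@H]1Cc2nccnc2CN1)[C@H]1CCCc2cccnc21` gives 2 nm/s
Compound 3 `NC(=O)NCCCCN(C[C@H]1Cc2ncccc2CN1)[C@H]1CCCc2cccnc21` gives 7 nm/s

Compound 3 stands highest of the three, and its gaps to compound 1 and to compound 2 both lie beyond the scatter. Compound 4 `CN(CCCCN(C[C@H]1Cc2ncccc2CN1)[C@H]1CCCc2cccnc21)C1CCOCC1` has not yet been measured in this assay. It keeps the core of compound 3 and differs from it as follows: methyl(oxan-4-yl)amino in place of ureido on a saturated chain carbon, four bonds along the chain from an amine nitrogen.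

Among the compounds with values here, no measured pair differs in one place only, so the evidence for this change is thin. Neither compound 1 at 2 nm/s nor compound 2 at 2 nm/s carries the ureido group. Compound 3, which does carry it, gives 7 nm/s. Compound 1 and compound 2 both lie lower than compound 3, although their cores differ as well. A modest fall is therefore expected, one that may stay within the scatter. The estimated change is a 1.8-fold lower number from compound 3 to compound 4 (0.24 log units; within the scatter). For compound 4 the expected value is 4 nm/s, with an estimated range from 1.5 nm/s to 11 nm/s.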

Compound 4, apparent permeability: 15 nm/s
For compound 4 the middle estimate is 3.8-fold (0.57 log units) below the measured one; the measured number lies above the stated range.
By their numbers in this assay, from the lowest: compounds 1 and 2 (each within the scatter of the next); then compound 3; then compound 4.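

Within the data shown here, this is the first pair that differs in one place only, so in this assay the change on a saturated chain carbon, four bonds along the chain from an amine nitrogen, can be read directly. Methyl(oxan-4-yl)amino in place of ureido gives a 2.1-fold higher number from compound 3 to compound 4 (0.33 log units; beyond the scatter) as a modest step, which shows that ureido is not required at this position for the higher number. Nothing shown gives a measured reason for this step.

The change alters several things at once, as the entering group has more heavy atoms, a six-membered non-aromatic ring and no hydrogen-bond donors, and the compounds shown do not separate these features. Also open, from the compounds shown here alone, is how a dimethylamino group or a carboxylic acid at this position would read, and whether the step holds on the other cores.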